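The source may report more compounds than this note shows. Statements on the series, on what has been measured and on what is new or still open speak of the compounds shown alone.

Measured in an assay on LM cells for displacement of a labelled ligand from Neuropeptide Y receptor type 5 (Homo sapiens); a higher number here means a weaker inhibitor, a lower number a stronger inhibitor:

compound 1 `Fc1ccc(C2(c3ccc(F)cc3)CNC(c3cccc(C(F)(F)F)c3)=N2)cc1`: 6.2 nM
compound 2 `Fc1ccc(C2(c3ccc(F)cc3)CNC(c3cccc(Br)c3)=N2)cc1`: 4.8 nM
compound 3 `Cc1cccc(C2=NC(c3ccc(F)cc3)(c3ccc(F)cc3)CN2)c1`: 30 nM

Compound 3 carries the highest number of the three. The two steps leading to it, a 4.8-fold higher number from compound 1 to compound 3 (0.68 log units; beyond the scatter) and a 6.3-fold higher number from compound 2 to compound 3 (0.80 log units; beyond the scatter), both lie beyond the scatter, so compound 3 is the weakest of the measured set in this assay. Compounds 1 and 2 themselves are not separable: a 1.3-fold lower number from compound 1 to compound 2 (0.11 log units; within the scatter) sits within the scatter.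

Compound 4 `CN(C)c1cccc(C2=NC(c3ccc(F)cc3)(c3ccc(F)cc3)CN2)c1` differs from compound 3 by dimethylamino in place of methyl on an aromatic carbon. Among the measured compounds shown here, no measured step exchanges a group at this position for a dimethylamino group; the three steps known all move between methyl, bromo and trifluoromethyl, and they only show that the methyl variant, compound 3, gives a higher number than the other two. They therefore give no direct reading on compound 4, and the expectation rests on the weaker footing that a change away from methyl at this position has, in both measured cases, produced a lower number.

On that basis compound 4 is estimated at 20 nM, with a range from 5 nM to 80 nM. The expected step is a 1.5-fold lower number from compound 3 to compound 4 (0.18 log units; within the scatter), which, being small, is not to be counted on as beyond the scatter.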

Compound 4, half-maximal inhibitory concentration: > 1000 nM
Compound 4: only a limit was reported; the forecaster's own chance of this, stated with the estimate: 2%; at least 50-fold (1.69 log units) between middle value and limit.
By their numbers in this assay, from the lowest: compounds 2 and 1 (each within the scatter of the next); then compound 3. At a limit, above all of these: compound 4.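

In this assay the reading for compound 4 is a limit of the assay and not a number: the limit of > 1000 nM in this assay, at which 1 of the 4 values shown sits.

Read against that limit, the change is large from every measured neighbour: an at least 33-fold higher number from compound 3 to compound 4 (1.52 log units; beyond the scatter), an at least 200-fold higher number from compound 2 to compound 4 (2.31 log units; beyond the scatter) and an at least 160-fold higher number from compound 1 to compound 4 (2.20 log units; beyond the scatter), all beyond the scatter, whereas the widest step among methyl, bromo and trifluoromethyl was a 6.3-fold higher number from compound 2 to compound 3 (0.80 log units; beyond the scatter). Among the compounds shown here, this position, on an aromatic carbon meta to a large group, therefore does not reward every move away from methyl: the bromo and trifluoromethyl compounds 2 and 1 go to lower numbers than compound 3, while the 3-(dimethylamino)phenyl compound 4 goes sharply the other way, an outcome the earlier compounds gave no sign of.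

The compounds shown leave open whether the loss follows the nitrogen or the larger group, as the two enter together in dimethylamino; an unsubstituted amine, a methoxy group or an isopropyl group at this place would pull them apart. On these data alone, the real size of the steps to compound 4 also stays open, as only a limit is reported.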